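A few compounds are considered here, and "the series" means these few. Any claim that something is new, unique, unknown or untested is made for them only; others in the source may bear on it.

Among the measured compounds shown here, compound 2 `COc1ccc(/C=N/NC(=O)c2cccnc2Nc2cccc(C(F)(F)F)c2)c(OC)c1` gives 55.7% in a functional assay on the whole organism (strain Wistar) for inhibition, with Rattus norvegicus as the target, read by paw edema, with a stated time of 1 h, at a dose of 10 mg/kg by the intraperitoneal route (a lower number here means less inhibition, a higher number more inhibition at the dose given (going by the name of the read-out)), the lower of the two numbers known so far. Compound 1 `O=C(N/N=C/c1ccc(O)cc1)c1cccnc1Nc1cccc(C(F)(F)F)c1` gives 70.5% in this assay, and the step of a number 14.8 percentage points lower from compound 1 to compound 2 (beyond the scatter) accompanies the exchange of a 4-hydroxyphenyl for a 2,4-dimethoxyphenyl. Compound 3 `COc1ccc(/C=N/NC(=O)c2cccnc2Nc2cccc(C(F)(F)F)c2)cc1OC` differs from compound 2 as follows: 3,4-dimethoxyphenyl in place of 2,4-dimethoxyphenyl on a carbon with a double bond to nitrogen. For the measured compounds named here, no measured step exchanges one dimethoxyphenyl for another, so the single known step offers no direct guide. The step is therefore expected to lie within the scatter, estimated as a number 0.3 percentage points higher from compound 2 to compound 3 (within the scatter). Compound 3 is estimated at 56%, between 40% and 72%.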

Compound 3, a percentage reported as inhibition, in the whole organism at one dose (the size of the read-out at that dose, not a potency): 70%
Beside the measured number, compound 3's estimate is 14 percentage points below it; the range from low to high includes it.
By their numbers in this assay, from the lowest: compound 2; then compounds 3 and 1 (each within the scatter of the next).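

In this assay, the exchange of 2,4-dimethoxyphenyl for 3,4-dimethoxyphenyl on the carbon with a double bond to nitrogen goes with a number 14.3 percentage points higher from compound 2 to compound 3 (beyond the scatter) and shows that this position tells apart two groups of the same atoms. The step of a number 0.5 percentage points lower from compound 1 to compound 3 (within the scatter) then shows that replacing 4-hydroxyphenyl with a dimethoxyphenyl does not by itself bring the lower number seen for compound 2. Nothing available explains the difference between the two dimethoxyphenyl groups.

The compounds shown leave open how a phenyl carrying a single methoxy group, a chlorine or an amine would read at this position.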